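Cytotoxicity of a chloroquinoline hydrazone pair: a new aryl

The compounds below may be only part of what the source reports. "The series", "measured", "known", "first", "only" and "open" are said of these compounds alone.

Measured so far:
compound 1, `COc1cc(/C=N/NC(=O)CCN2CCN(c3ccnc4cc(Cl)ccc34)CC2)ccc1O`, 9400 nM
compound 2, `NNC(=O)CCN1CCN(c2ccnc3cc(Cl)ccc23)CC1`, > 100000 nM
compound 3, `O=C(CCN1CCN(c2ccnc3cc(Cl)ccc23)CC1)N/N=C/c1cccc(Cl)c1`, > 100000 nM

The three compounds share one core and differ only at the hydrazide end. In an ADME assay on cells (Splenocyte, Mus musculus, strain BALB/c) for cytotoxicity, read by thymidine incorporation, with a stated time of 24 h (on this read-out higher numbers stand for weaker inhibition and lower numbers for stronger inhibition), compound 1 gives 9400 nM. Compound 2 gives only a limit in this assay, > 100000 nM. Compound 3 likewise gives only a limit, > 100000 nM, and so stands with compound 2 at the limit of > 100000 nM in this assay, at which 2 of the 3 values shown sit.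

Two steps are readable. Removing the whole aryl hydrazone piece brings an at least 10-fold higher number from compound 1 to compound 2 (1.02 log units; beyond the scatter); swapping the aryl group alone brings an at least 10-fold higher number from compound 1 to compound 3 (1.02 log units; beyond the scatter). The step between compound 2 and compound 3 cannot be read from the two limits.

Compound 4, `CC(C)c1ccc(/C=N/NC(=O)CCN2CCN(c3ccnc4cc(Cl)ccc34)CC2)cc1`, differs from compound 3 by 4-isopropylphenyl in place of 3-chlorophenyl on a carbon with a double bond to nitrogen. Among the measured compounds shown here, the only step measured on that carbon, the one from compound 1 to compound 3, was large and in the direction of the limit, so weak inhibition is expected to persist. Compound 4 is therefore estimated at 100000 nM, within 30000 nM to 300000 nM, an expected step of a number no higher from compound 3 to compound 4 (the limit leaves the size open) that most likely stays at the limit.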

Compound 4, half-maximal inhibitory concentration: 7900 nM
Compound 4: the middle estimate sits 13-fold (1.10 log units) above what was measured, and the stated range ends above it.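

In this assay, 4-isopropylphenyl in place of 3-chlorophenyl on the carbon with a double bond to nitrogen gives an at least 12-fold lower number from compound 3 to compound 4 (1.10 log units; beyond the scatter), so changing the group at this position does not in itself lead to the limit. The comparison with the parent hydrazone gives a 1.2-fold lower number from compound 1 to compound 4 (0.08 log units; within the scatter), so the hydroxy and methoxy groups of compound 1 are not required for a value of this order. The 4-isopropylphenyl hydrazone also gives an at least 12-fold lower number from compound 2 to compound 4 (1.10 log units; beyond the scatter) against the bare hydrazide, yet a hydrazone alone is not sufficient, as compound 3 remains at a limit: the limit of > 100000 nM in this assay, at which 2 of the 4 values shown sit.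

As far as these compounds go, whether the chlorine itself or its place on the aryl group separates compound 3 from compound 4 stays open, and a 4-chlorophenyl group would bear on that. From the compounds shown here alone, how an aryl group carrying an amine or a carboxylic acid would behave also remains unknown.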